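From 4-carboxyphenyl to 3-carboxyphenyl in compound 4

This account rests on a few compounds, and the source may have more. Where it says the series, first, only, none or still open, it means among the compounds named here.

- compound 1 `CCCCCCCCc1ccc(OCC(=O)Cn2nnnc2-c2cccc(Cl)c2)cc1`: 41%
- compound 2 `CCCCCCCCc1ccc(OCC(=O)Cn2nnnc2C(=O)OCC)cc1`: 33%
- compound 3 `CCCCCCCCc1ccc(OCC(=O)Cn2nnnc2-c2ccc(C(=O)O)cc2)cc1`: 6%

In an ADME assay on S9 fraction from liver (Rattus norvegicus) for metabolic stability, read by LC-MS, using NADPH, with a stated time of 30 min (on this read-out lower numbers stand for a less stable compound and higher numbers for a more stable compound), compound 3 stands lowest of the three, at 6%. Two measured steps reach it: a number 35 percentage points lower from compound 1 to compound 3 (beyond the scatter), and a number 27 percentage points lower from compound 2 to compound 3 (beyond the scatter). Both bring in 4-carboxyphenyl, while a number 8 percentage points lower from compound 1 to compound 2 (within the scatter) involves no carboxyphenyl group. Compound 4 `CCCCCCCCc1ccc(OCC(=O)Cn2nnnc2-c2cccc(C(=O)O)c2)cc1` has the same atoms as compound 3, joined differently: 3-carboxyphenyl in place of 4-carboxyphenyl on an aromatic carbon, with 3-carboxyphenyl in place of 4-carboxyphenyl. Among the measured compounds shown here, no measured step shifts a group in this way. Compound 4 still carries a carboxyphenyl group, so no change beyond the scatter is expected, and the large a number 35 percentage points lower from compound 1 to compound 3 (beyond the scatter) is not expected to be reversed. The expected step is a number 4 percentage points higher from compound 3 to compound 4 (within the scatter). For compound 4 the estimate is 10%, with an expected range of 3% to 25%.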

Compound 4, percent of the compound remaining: < 5%
Compound 4: only a limit was reported (the forecaster's own chance of this, stated with the estimate: 2%); at least 5 percentage points between middle value and limit.
By their numbers in this assay, from the lowest: compound 3; then compounds 2 and 1 (each within the scatter of the next). At a limit, below all of these: compound 4.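

Compound 4 gives only a limit in this assay, not a number: the limit of < 5% in this assay, at which 1 of the 4 values shown sits. Shifting the carboxy group, with 3-carboxyphenyl in place of 4-carboxyphenyl, gives a number at least 1 percentage points lower from compound 3 to compound 4 (that floor lies within the scatter), so the low reading is not confined to the 4-carboxyphenyl compound. The other two steps show a number at least 28 percentage points lower from compound 2 to compound 4 (beyond the scatter) and a number at least 36 percentage points lower from compound 1 to compound 4 (beyond the scatter), the latter a single swap of carboxy in place of chloro, which ties the low reading to the carboxy group without a shift of position.

From the compounds shown here alone, how far compound 4 lies under its limit stays open. So does how an amide or a primary amine in place of the carboxy group would read.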